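This account rests on a few compounds, and the source may have more. Where it says the series, first, only, none or still open, it means among the compounds named here.

Measured so far:
compound 1, `O=c1oc2ccccc2n1Cc1ccc(Cl)cc1`: 35000 nM
compound 2, `O=c1oc2ccc(Cl)cc2n1Cc1ccc(Cl)cc1`: 6080 nM
compound 3, `O=C(Cc1ccc(F)cc1)n1c(=O)oc2ccccc21`: > 100000 nM

In an assay on HeLa cells for inhibition of Indoleamine 2,3-dioxygenase 1 (Homo sapiens), with a stated time of 24 h (on this read-out lower numbers stand for stronger inhibition and higher numbers for weaker inhibition), compound 1 gives 35000 nM. Compound 2 differs from compound 1 by chloro in place of hydrogen on an aromatic carbon, and in this assay compound 2 gives 6080 nM, a step of a 5.8-fold lower number from compound 1 to compound 2 (0.76 log units; beyond the scatter). For compound 3 the assay reports only a limit, > 100000 nM, so no number is known for it. That is the limit of > 100000 nM in this assay, at which 1 of the 3 values shown sits. How the core of compound 3 differs from the core of compound 1 is not broken down here.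

Compound 4, `O=C(Cc1ccc(F)cc1)n1c(=O)oc2ccc(Cl)cc21`, is not yet measured. It differs from compound 3 by chloro in place of hydrogen on an aromatic carbon, the same change, at the same kind of place, as from compound 1 to compound 2. Compound 4 is therefore expected to sit somewhat lower than the limit seen for compound 3, with an expected step of about an at least 2.0-fold lower number from compound 3 to compound 4 (0.30 log units; that floor lies within the scatter), because the same change gave a 5.8-fold lower number from compound 1 to compound 2 (0.76 log units; beyond the scatter). Since the starting point is only a limit, the expectation is loose: compound 4 is estimated at 50000 nM, most likely between 15000 nM and 200000 nM.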

Compound 4, half-maximal inhibitory concentration: 6400 nM
The estimate for compound 4 lay 7.8-fold (0.89 log units) above the measured number, outside the stated range (below it).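

In this assay, chloro in place of hydrogen on an aromatic carbon lowers the number on both cores, and the new step is an at least 15-fold lower number from compound 3 to compound 4 (1.19 log units; beyond the scatter). Compound 3 has only a limit, > 100000 nM, which is not a number, so this step gives a minimum size and not an exact one. With only two pairs, the change carries over from one core to the other in direction but not in size, and these results neither explain the gap nor give a rule for other cores: the same change on two cores in this assay, a 5.8-fold lower number (0.76 log units; beyond the scatter) from compound 1 to compound 2 and an at least 15-fold lower number (1.19 log units; beyond the scatter) from compound 3 to compound 4, at least 2.7-fold (0.43 log units) apart, beyond the scatter of two such steps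

Among the compounds shown, this place on the ring holds only hydrogen or chloro, so it remains open whether fluoro, methoxy or trifluoromethyl there would also lower the number. Going by these compounds, it is also open how the step would behave on a core with a longer chain leading to the outer ring, or with an amine on that ring.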